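The compounds below may be only part of what the source reports. "The series", "measured", "known", "first", "only" and "open" are said of these compounds alone.

Measured so far:
- compound 1, `COc1cccc(CNCCCNc2ccnc3cc(C4CCCCC4)ccc23)c1O`: 1080 nM
- compound 2, `COc1ccc(F)cc1CNCCCNc1ccnc2cc(C3CCCCC3)ccc12`: 2290 nM
- compound 3, `COc1ccc(-c2ccc3c(NCCCNCc4ccco4)ccnc3c2)cc1`: 6000 nM

These three compounds were tested in an ADME assay on HepG2 cells (Homo sapiens) for cytotoxicity, read by luminescence, CellTiter-Glo and ATP content, with a stated time of 72 h; on this read-out higher numbers stand for an effect only at larger amounts of compound and lower numbers for an effect already at smaller amounts. Compound 1 gives the lowest of the three numbers, so it acts on the cells already at the smallest amount. Among the measured compounds shown here, the only single change measured is a 2.1-fold higher number from compound 1 to compound 2 (0.33 log units; beyond the scatter), which alters the group on the chain carbon bound to the amine nitrogen, far from the part of the molecule that is changed in compound 4. Compound 3 differs from compound 1 in two places at once; compound 3 gives 6000 nM, which can only say that a compound with a different group on the shared core and a different group at the chain end landed well above the number seen for the first compound.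

The new compound 4, `COc1ccc(Oc2ccc3c(NCCCNCc4cccc(OC)c4O)ccnc3c2)cc1`, differs from compound 1 as follows: 4-methoxyphenoxy in place of cyclohexyl on an aromatic carbon. For the measured compounds named here, no measured step touches this exact change, so the expectation rests on the general spread of the three numbers. A modest rise is expected, a 2.3-fold higher number from compound 1 to compound 4 (0.36 log units; beyond the scatter), with wide uncertainty. Compound 4 is therefore estimated at 2500 nM, within a range from 800 nM to 8000 nM.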

Compound 4, half-maximal effective concentration: 5500 nM
Compound 4: the middle estimate sits 2.2-fold (0.34 log units) below what was measured; the measured number falls inside the stated range.
By their numbers in this assay, from the lowest: compound 1; then compound 2; then compounds 4 and 3 (each within the scatter of the next).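

In this assay, putting 4-methoxyphenoxy in place of cyclohexyl on this aromatic carbon of the shared core gives a 5.1-fold higher number from compound 1 to compound 4 (0.71 log units; beyond the scatter), so a change at this position moves the number beyond the usual scatter. In size, this step exceeds a 2.1-fold higher number from compound 1 to compound 2 (0.33 log units; beyond the scatter), the only other single change shown, which replaces the group on the chain carbon bound to the amine nitrogen, though two steps are too few to support a general rule about the two sites. Nothing available explains the rise in the number from the cyclohexyl compound to the 4-methoxyphenoxy compound.

This one swap alters several things at once, exchanging a non-aromatic ring for an aromatic one, raising the heavy-atom count and bringing in oxygen atoms, and the compounds shown cannot separate these changes. A plain phenyl or an unsubstituted phenoxy at the same carbon, set on the otherwise unchanged structure of compound 1, would help show whether the aromatic ring, the linking oxygen or the methoxy group goes with the higher number.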